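Dichlorinated Purine Benzyl Chlorides: Cytotoxicity Working Notes

The source may hold more compounds than are shown below. What is called first, only, known or untested is meant among the compounds shown, and "the series" means these compounds.

Measured so far in a functional assay on U-251 cells (Homo sapiens) for cytotoxicity, read by sulforhodamine B assay, with a stated time of 48 h; on this read-out higher numbers stand for lower toxicity in this test and lower numbers for higher toxicity in this test:
compound 1, `ClCc1ccccc1Cn1cnc2c(Cl)nc(Cl)nc21`; compound 1 gives 4570 nM
compound 2, `ClCc1ccccc1Cn1cnc2c(Cl)ncnc21`; compound 2 gives 61700 nM
compound 3, `ClCc1cccc(Cn2cnc3c(Cl)ncnc32)c1`; compound 3 gives 6760 nM

Among the measured compounds shown here, the one change measured on its own is chloro in place of hydrogen on an aromatic carbon, which produced a 14-fold lower number from compound 2 to compound 1 (1.13 log units; beyond the scatter). Compound 3 and compound 2 are built from the same atoms joined differently; the difference between the two cores is not broken down here. Compound 3 stands near compound 1 in this assay, the two within the usual scatter, while the gap from compound 2 to compound 3 lies beyond it.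

Compound 4, `ClCc1cccc(Cn2cnc3c(Cl)nc(Cl)nc32)c1`, has not yet been measured in this assay. Relative to compound 3 it carries chloro in place of hydrogen on an aromatic carbon, the same change at the same kind of place as the measured one, the two place descriptions agreeing word for word. The same step is expected in this assay for compound 4, namely an 11-fold lower number from compound 3 to compound 4 (1.05 log units; beyond the scatter), because compound 2 to compound 1 gave a 14-fold lower number from compound 2 to compound 1 (1.13 log units; beyond the scatter). Compound 4 is therefore estimated at 600 nM, with a likely range of 200 nM to 2000 nM.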

Compound 4, concentration lethal to 50% of the cells: 5620 nM
For compound 4 the middle estimate is 9.4-fold (0.97 log units) below the measured one; the measured number lies above the stated range.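

In this assay, chloro in place of hydrogen on an aromatic carbon gives a 1.2-fold lower number from compound 3 to compound 4 (0.08 log units; within the scatter), a step that stays within the scatter, so the large step seen on the core of compound 2 does not carry over to the core of compound 3. The same change therefore cannot be treated as a fixed increment across these two cores: the same change on two cores in this assay, a 14-fold lower number (1.13 log units; beyond the scatter) from compound 2 to compound 1 and a 1.2-fold lower number (0.08 log units; within the scatter) from compound 3 to compound 4, 11-fold (1.05 log units) apart, beyond the scatter of two such steps. This shows that the size of the step depends on the core in these two pairs, but it does not show which difference between the cores is responsible or how the step would behave on any further core.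

Still open, on these data alone, is whether an amine or a methoxy group entering at the same place, between two ring nitrogen atoms, would also give steps that differ between the two cores. Also open, as far as these compounds go, is whether replacing the chloro on the benzyl side chain with a hydroxyl group would alter the contrast seen here.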